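Working notes: E to Z change at compound 3

The source may hold more compounds than are shown below. What is called first, only, known or untested is meant among the compounds shown, and "the series" means these compounds.

- compound 1 `COc1ccc(/C=C\c2ccc3ccccc3c2)cc1[N+](=O)[O-]`: > 20000 nM
- compound 2 `COc1c([N+](=O)[O-])cc(/C=C/c2ccc3ccccc3c2)cc1[N+](=O)[O-]`: > 5000 nM

Both entries come from a functional assay on A549 cells (Homo sapiens) for inhibition (a higher number here means a weaker inhibitor, a lower number a stronger inhibitor), and both are limits, not numbers. As far as these compounds go, compound 2 stands only at its limit of > 5000 nM, so its true position is unknown. Compound 3 `COc1c([N+](=O)[O-])cc(/C=C\c2ccc3ccccc3c2)cc1[N+](=O)[O-]` is still to be measured, and its relation to compound 2 is the two compounds have the same atoms and bonds and differ only in configuration as drawn: 1 of 1 stereo elements differ; a double bond is drawn E in compound 2 and Z in compound 3. Compound 1, also drawn Z, reaches only its limit of > 20000 nM, so a large gain is not expected. For the measured compounds named here, the expected change is a step that the limit leaves unreadable from compound 2 to compound 3, with no step expected beyond the scatter. Compound 3 is estimated at 8000 nM in this assay, within an expected range of 1500 nM to 30000 nM.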

Compound 3, half-maximal inhibitory concentration: > 5000 nM
Compound 3: no number, only a limit (the forecaster's own chance of this, stated with the estimate: 65%); the middle value does not contradict the limit.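

Compound 3 gives only a limit, so neither the step to it from compound 2 nor the step from compound 1 can be read. Still open, as far as these compounds go, is whether the change from E to Z or the added nitro alters inhibition at all; compound 1, compound 2 and compound 3 all stand at limits.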